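The source may hold more compounds than are shown below. What is called first, only, known or untested is meant among the compounds shown, and "the series" means these compounds.

Notes on the series as read in a functional assay on K562 cells (Homo sapiens), read by MTT assay, with a stated time of 72 h (on this read-out higher numbers stand for weaker inhibition and lower numbers for stronger inhibition), so far. Compound 1 (`CSc1ncnc2c1c(-c1ccccc1)cn2[C@@H]1O[C@H](CO)[C@@H](O)[C@H]1O`) gives > 20000 nM in this read-out, which is a limit and not a number. Within the data shown here, compound 2 (`CNc1ncnc2c1c(-c1ccco1)cn2[C@@H]1O[C@H](CO)[C@@H](O)[C@H]1O`) gives 15100 nM as the only actual number available, a high figure that stands for weak inhibition. Compound 3 (`CNc1ncnc2c1c(-c1ccsc1)cn2[C@@H]1O[C@H](CO)[C@@H](O)[C@H]1O`) differs from compound 2 in one place, with thiophen-3-yl in place of furan-2-yl on an aromatic carbon of a five-membered aromatic ring with 1 nitrogen (thiophen-3-yl in place of furan-2-yl on an aromatic carbon). Among the measured compounds shown here, no measured pair sizes this exchange. No step beyond the usual scatter is expected in this assay and neither direction is favoured. The expected move a 1.3-fold lower number from compound 2 to compound 3 (0.10 log units; within the scatter) is therefore small. Compound 3 is expected at 12000 nM within an estimated range of 3500 nM to 20000 nM on present data.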

Compound 3, half-maximal inhibitory concentration: > 20000 nM
Compound 3: only a limit was reported (the forecaster's own chance of this, stated with the estimate: 35%); middle value at least 1.6-fold (0.22 log units) away from the limit.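

In this assay compound 3 gives > 20000 nM, which is a limit and not a number. On these data alone, at this aromatic carbon, the exchange of furan-2-yl for thiophen-3-yl can therefore be read only as a floor, an at least 1.3-fold higher number from compound 2 to compound 3 (0.12 log units; that floor lies within the scatter), so its true size remains unknown and it does not show a lower number. With compound 2 the only compound giving an actual number, the read-out offers little room to rank changes at this position: the limit of > 20000 nM in this assay, at which 2 of the 3 values shown sit.

The compounds shown leave open whether the change of hetero atom or the change of ring attachment matters here, since furan-3-yl and thiophen-2-yl do not appear among them. They also leave open whether a non-aromatic group at this carbon, such as an aminomethyl group or a carboxylic acid, would give a lower number than compound 2.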